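Hydroxy for Methyl on the Chain: Compound 4 Expected

A few compounds are considered here, and "the series" means these few. Any claim that something is new, unique, unknown or untested is made for them only; others in the source may bear on it.

Measured so far:
compound 1, `CCCn1c(N)c(-c2nc3ccccc3[nH]2)c2nc(C#N)c(C#N)nc21`, > 50000 nM
compound 2, `N#Cc1nc2c(-c3nc4ccccc4[nH]3)c(N)n(CCO)c2nc1C#N`, 5520 nM
compound 3, `CCCCn1c(N)c(-c2nc3ccccc3[nH]2)c2nc(C#N)c(C#N)nc21`, > 50000 nM

Three compounds share a core and differ only in the chain on the aromatic nitrogen. In a functional assay on Raji cells (Homo sapiens) for antiproliferative activity, read by MTT assay, with a stated time of 48 h (on this read-out higher numbers stand for weaker inhibition and lower numbers for stronger inhibition), compound 1 gives > 50000 nM, which is a limit of the assay and not a number. Compound 2 differs from compound 1 by hydroxy in place of methyl on a saturated chain carbon, two bonds along the chain from an aromatic nitrogen; in this assay compound 2 gives 5520 nM, and the step is an at least 9.0-fold lower number from compound 1 to compound 2 (0.95 log units; beyond the scatter). Compound 3 differs from compound 1 by methyl in place of hydrogen on a saturated chain carbon, three bonds along the chain from an aromatic nitrogen. In this assay compound 3 gives > 50000 nM, again a limit and not a number. The step that the two limits leave unreadable from compound 1 to compound 3 cannot be sized, since the limit of > 50000 nM in this assay, at which 2 of the 3 values shown sit, covers both ends. The step of an at least 9.0-fold higher number from compound 2 to compound 3 (0.95 log units; beyond the scatter) is the reverse picture of the first.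

Compound 4, `N#Cc1nc2c(-c3nc4ccccc4[nH]3)c(N)n(CCCO)c2nc1C#N`, has not yet been measured. It differs from compound 3 by hydroxy in place of methyl on a saturated chain carbon, three bonds along the chain from an aromatic nitrogen. This is the same kind of change as that from compound 1 to compound 2, not the same: there the place is two bonds along the chain from an aromatic nitrogen, here it is three bonds along the chain from an aromatic nitrogen. In this assay a step of an at least 6.2-fold lower number from compound 3 to compound 4 (0.79 log units; beyond the scatter) is expected, beside an at least 9.0-fold lower number from compound 1 to compound 2 (0.95 log units; beyond the scatter), resting on the step of an at least 9.0-fold lower number from compound 1 to compound 2 (0.95 log units; beyond the scatter) being the only sized one shown. Compound 4 is therefore estimated at 8000 nM, between 2000 nM and 45000 nM.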

Compound 4, half-maximal inhibitory concentration: > 50000 nM
Compound 4 ended at the assay's limit (the forecaster's own chance of this, stated with the estimate: 25%); middle value at least 6.2-fold (0.79 log units) from the limit.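

In this assay compound 4 gives > 50000 nM, which is a limit of the assay and not a number. Among the compounds shown here, the steps to compound 4 from compound 3 and from compound 1 cannot be read, because a limit stands at both ends of each: the limit of > 50000 nM in this assay, at which 3 of the 4 values shown sit. The one readable step is an at least 9.0-fold higher number from compound 2 to compound 4 (0.95 log units; beyond the scatter), so the lower number that hydroxy in place of methyl gave at two bonds along the chain from an aromatic nitrogen, an at least 9.0-fold lower number from compound 1 to compound 2 (0.95 log units; beyond the scatter), did not appear in any readable form when the same change was carried to three bonds along the chain, although this does not show that the change did nothing there, as any difference between compound 3 and compound 4 remains hidden at the limit.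

Compound 2 is the only compound shown that gives a number, so a single chain, 2-hydroxyethyl, carries all that is known of activity in this series, and whether the result at three bonds along the chain holds more widely stays undecided. The compounds shown leave open what a methoxy group or an amine at the end of the 2-hydroxyethyl chain would give in this assay, and whether a carboxylic acid or a longer chain ending in hydroxy would give a number at all.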